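A few compounds are considered here, and "the series" means these few. Any claim that something is new, unique, unknown or untested is made for them only; others in the source may bear on it.

Three compounds have numbers in a physicochemical assay for activation, with a stated time of 60 min (a higher number here means that more compound is needed for the effect, a lower number that less compound is needed), so far:
compound 1 `NC(=O)N1C(=O)/C(=C(\O)c2ccc(F)s2)c2cc(F)c(Cl)cc21` gives 833000 nM
compound 2 `O=C1NC(=O)/C(=C\c2ccc(Cl)cc2)C2=C1CCCC2` gives 500 nM
compound 3 `CCCCCc1ccc(/C=C2\C(=O)NC(=O)C3=C2CCCC3)cc1` gives 9200 nM

Compound 3 holds the second highest of these three numbers, above compound 2 and under compound 1. The next compound to be measured is compound 4 `O=C1NC(=O)/C(=C\c2ccc(C(=O)O)cc2)C2=C1CCCC2`, which keeps the core of compound 3 and changes one group: carboxy in place of pentyl on an aromatic carbon, para to a large group (carboxy in place of pentyl on an aromatic carbon).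

For the measured compounds named here, only one measured step involves pentyl, and it is large: swapping chloro for pentyl on an aromatic carbon gave an 18-fold higher number from compound 2 to compound 3 (1.26 log units; beyond the scatter), so losing pentyl may well lower the number in this assay. Going by the values given here, no measured compound carries carboxy, however, so the size of that drop is uncertain, and it could be smaller than the earlier rise. What is expected is a 3.1-fold lower number from compound 3 to compound 4 (0.49 log units; beyond the scatter), a modest step downward. The estimate for compound 4 is 3000 nM with an expected range from 300 nM to 30000 nM in this assay.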

Compound 4, half-maximal effective concentration: 53000 nM
For compound 4 the middle estimate is 18-fold (1.25 log units) below the measured one; measured number outside the range, above it.
By their numbers in this assay, from the lowest: compound 2; then compound 3; then compound 4; then compound 1.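

At this position, on the aromatic carbon para to a large group, removing pentyl did not lower the number: carboxy in its place gave a 5.8-fold higher number from compound 3 to compound 4 (0.76 log units; beyond the scatter) in this assay. Compared with chloro, carboxy gives a 110-fold higher number from compound 2 to compound 4 (2.03 log units; beyond the scatter), so chloro has the lowest number of the three groups, with pentyl, which has no hydrogen-bond donor, and carboxy, which has one, both higher. Carboxy also has fewer heavy atoms than pentyl yet the higher number, so the heavy-atom count does not by itself set the order of these two groups.

Nothing available here explains this order. Going by these compounds, it remains open whether a methyl group or a fluorine atom at this position would stay close to chloro, and whether an amine would fall nearer to carboxy.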